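Piperidinyl ether in place of aminomethyl-oxetane ether

This account rests on a few compounds, and the source may have more. Where it says the series, first, only, none or still open, it means among the compounds named here.

Compound 3 `Cc1n[nH]c2nc(-c3ccc(NS(=O)(=O)c4cc(Cl)ccc4F)cc3)nc(OCC3(CN)COC3)c12` carries an aryl-sulfonamide shared with compound 1 `CC(C)NC(=O)c1cc(-c2ccc(NS(=O)(=O)c3cccc(Cl)c3Cl)cc2)nc2[nH]ncc12` and compound 2 `NCCNC(=O)c1cc(-c2ccc(NS(=O)(=O)c3cccc(Cl)c3Cl)cc2)nc2[nH]ncc12`, with a different substitution pattern on the sulfonyl-bearing ring and an ether on the core. In an assay for inhibition of serine/threonine-protein kinase Sgk1 (Homo sapiens), with stated times of 30 min and 60 min, in the presence of a further agent that is not named here (on this read-out higher numbers stand for weaker inhibition and lower numbers for stronger inhibition), compound 3 gives 1 nM, the lowest of the two numbers in hand; compound 1 gives 68 nM, so compound 3 lies well below it. Compound 2 sits at the assay limit of < 1 nM, not a number (the limit of < 1 nM in this assay, at which 1 of the 3 values shown sits). Going by the values given here, the one measured step, an at least 68-fold lower number from compound 1 to compound 2 (1.83 log units; beyond the scatter), shows that a chain bearing an amine nitrogen and a hydrogen-bond donor brought a large fall in the number.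

Compound 4 `CCN1CCCC(Oc2nc(-c3ccc(NS(=O)(=O)c4cc(Cl)ccc4F)cc3)nc3[nH]nc(C)c23)C1` differs from compound 3 in one place: 1-ethylpiperidin-3-yl in place of (3-(aminomethyl)oxetan-3-yl)methyl on an oxygen on an aromatic ring. The leaving group carried the aminomethyl and its one hydrogen-bond donor; the entering group carries a ring nitrogen and no donor. The step from compound 1 to compound 2 bears on this only indirectly, since there a donor-bearing amine chain entered rather than left; its large size suggests the loss of the aminomethyl may cost something, tempered by the nitrogen that the piperidinyl ring retains. A modest rise in this assay is therefore expected, near the edge of the scatter: for compound 4 the estimate is 3 nM, between 0.8 nM and 12 nM, an expected step of a 3.0-fold higher number from compound 3 to compound 4 (0.48 log units; beyond the scatter).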

Compound 4, half-maximal inhibitory concentration: 6 nM
Estimate against measurement, compound 4: 2.0-fold (0.30 log units) below, within the range that was stated.
By their numbers in this assay, from the lowest: compound 3; then compound 4; then compound 1.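

The oxygen on the aromatic ring accepts a complete exchange of its substituent at a modest cost: a 6.0-fold higher number from compound 3 to compound 4 (0.78 log units; beyond the scatter) in this assay. Going by these compounds alone, this is the first reading at this position, since the earlier step concerned an amide-type nitrogen on a different core, and it shows that 1-ethylpiperidin-3-yl, with 0 hydrogen-bond donors, keeps compound 4 at 6 nM, whereas (3-(aminomethyl)oxetan-3-yl)methyl carries 1 hydrogen-bond donor. Both ends of this step are numbers, so its size can be read as it stands, and the only limit in the set belongs to compound 2: the limit of < 1 nM in this assay, at which 1 of the 4 values shown sits.

This single step changes the ring, the nitrogen and the ethyl group together, so it cannot assign the rise to any one of them. A piperidin-3-yl group with a free ring amine, or a 3-aminopropyl chain on the same oxygen, would show whether a hydrogen-bond donor on this substituent matters apart from the ring that carries it.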